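This account rests on a few compounds, and the source may have more. Where it says the series, first, only, none or still open, it means among the compounds named here.

Three compounds share one core and differ only in the group carried on one aromatic carbon of the triazole ring. Compound 1 `COc1ccc(-n2nc(-c3ccccc3)nc2CNc2ccc(C(=O)NO)cc2)cc1` gives 63.4% in an assay on Sf9 cells for inhibition of protein deacetylase HDAC6 (Homo sapiens), read by fluorescence, with a stated time of 40 min, tested at 100 nM; a higher number here means more inhibition at the concentration tested (going by the name of the read-out), a lower number less inhibition. Compound 3 `Cc1ccc(-n2nc(-c3ccccc3)nc2CNc2ccc(C(=O)NO)cc2)cc1` gives 60.7%, and a number 2.7 percentage points lower from compound 1 to compound 3 (within the scatter). Compound 2 `O=C(NO)c1ccc(NCc2nc(-c3ccc(Br)cc3)nn2-c2ccccc2)cc1` gives 54.7%; the numbers of compound 1 and compound 3 each lie within the usual scatter of it, so the three measured compounds cannot be told apart on these numbers.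

Compound 4 `O=C(NO)c1ccc(NCc2nc(-c3ccsc3)nn2-c2ccccc2)cc1` is the unmeasured compound. It differs from compound 2 by thiophen-3-yl in place of 4-bromophenyl on an aromatic carbon. Among the compounds with values here, no measured pair changes this group: the only measured step exchanges methyl and methoxy on a different ring, and that step stayed within the scatter. Within the data shown here, there is therefore no measured step that bears on this change, and no direction can be drawn from the data; the expectation is a step of no clear direction, not beyond the scatter, so that a number 0.3 percentage points higher from compound 2 to compound 4 (within the scatter) is expected. Compound 4 is estimated to give 55%, with a range from 35% to 75%.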

Compound 4, a percentage reported as inhibition, at one concentration (the size of the read-out at that concentration, not a potency): 53.4%
Beside the measured number, compound 4's estimate is 1.6 percentage points above it; low and high end bracket the measured number.
By their numbers in this assay, from the lowest: compounds 4, 2, 3 and 1 (each within the scatter of the next).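

In this assay, replacing 4-bromophenyl with thiophen-3-yl gives a number 1.3 percentage points lower from compound 2 to compound 4 (within the scatter). This is the first step shown at this aromatic carbon, between two ring nitrogen atoms, and it is also the first to change the group there. A six-membered carbon ring of 7 heavy atoms, bromine included, gives way to a five-membered sulfur-containing ring of 5 heavy atoms, yet the two compounds cannot be told apart at the single concentration tested. No supporting evidence is available to explain this result.

From the compounds shown here alone, it remains open whether a group without an aromatic ring at this carbon, such as an amine, a carboxylic acid or a longer alkyl chain, would give a step beyond the scatter. A single-concentration read-out also leaves open whether compound 2 and compound 4 differ in potency.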